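Swapping the para substituent: from chloro to nitro

A few compounds are considered here, and "the series" means these few. Any claim that something is new, unique, unknown or untested is made for them only; others in the source may bear on it.

Of the compounds shown here, two of one shared core have been measured. Compound 1 `O=C(/C=C/c1ccc2c(c1)B(O)OC2)c1ccc(F)cc1` carries a fluoro group, and in a functional assay on SK-OV-3 cells (Homo sapiens) for cytotoxicity, read by MTT assay, with a stated time of 48 h (on this read-out higher numbers stand for weaker inhibition and lower numbers for stronger inhibition), compound 1 gives 1400 nM. Compound 2 `O=C(/C=C/c1ccc2c(c1)B(O)OC2)c1ccc(Cl)cc1` carries a chloro group in the same position, and in this assay compound 2 gives 3700 nM. Among the compounds with values here, compound 2 therefore stands at the highest of the two numbers seen so far, meaning the weaker of the two inhibitions: the single step recorded, a 2.6-fold higher number from compound 1 to compound 2 (0.42 log units; beyond the scatter), comes from chloro in place of fluoro on an aromatic carbon and is modest but beyond the scatter.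

Compound 3 `O=C(/C=C/c1ccc2c(c1)B(O)OC2)c1ccc([N+](=O)[O-])cc1` is the next in line. Its difference from compound 2 is nitro in place of chloro on an aromatic carbon, on an aromatic carbon of a six-membered aromatic ring of carbon only, para to a large group. Within the data shown here, no measured pair shows nitro entering, so the only guidance is that a change at this same position, from compound 1 to compound 2, moved the number modestly. A step of similar modest size in either direction is therefore expected, with no firm basis for picking a side.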

Compound 3, half-maximal inhibitory concentration: 7900 nM
Beside the measured number, compound 3's estimate is 2.6-fold (0.42 log units) below it; measured number inside the range.
By their numbers in this assay, from the lowest: compound 1; then compound 2; then compound 3.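

In this assay, this position on the aromatic ring, para to a large group, now carries three different groups, and the number rises with each replacement. The step of a 2.1-fold higher number from compound 2 to compound 3 (0.33 log units; beyond the scatter) runs the same way as the earlier change from fluoro to chloro, so the first shift in inhibition is no longer an isolated pair, and no compound among these three goes against the order. Taken end to end, the step of a 5.6-fold higher number from compound 1 to compound 3 (0.75 log units; beyond the scatter) shows that the choice of group here spans a wider range than the first pair revealed, with the fluoro group of compound 1 still giving the lowest number and so the strongest inhibition of the three. Nothing measured here explains why the groups fall in this order.

The compounds shown leave open whether an amine, a methoxy group or a plain hydrogen at this position would continue the same order or give a number lower than that of compound 1. They also leave open whether this order would hold if another part of the shared core were changed, since all three compounds differ only at this one position.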